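Changing the aromatic group on a weak compound

The source may report more compounds than this note shows. Statements on the series, on what has been measured and on what is new or still open speak of the compounds shown alone.

In a functional assay on KYSE-70 cells for antiproliferative activity against KYSE-70 cell line (Homo sapiens), read by MTT assay, with a stated time of 72 h (on this read-out lower numbers stand for stronger inhibition and higher numbers for weaker inhibition), compound 1 `O=C(Nc1cccc(F)c1)c1cc(=O)[nH]c2cc(Br)ccc12` gives 8900 nM. Compound 2 `O=C(Nc1cccc(F)c1)c1cc(=O)[nH]c2cc(-c3ccncc3)ccc12` gives > 20000 nM, which is a limit of the assay and not a number. The two differ in one place, where pyridin-4-yl stands in place of bromo on an aromatic carbon.

Compound 3 `Nc1ccc(-c2ccc3c(C(=O)Nc4cccc(F)c4)cc(=O)[nH]c3c2)cc1` keeps the shared core and changes that same group, with 4-aminophenyl in place of pyridin-4-yl on an aromatic carbon.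

Among the measured compounds shown here, only one measured step bears on this change, and it is a single example that replaces bromo rather than one ring with another. Compound 2 carries a six-membered aromatic ring on this carbon, and the measured step of an at least 2.2-fold higher number from compound 1 to compound 2 (0.35 log units; beyond the scatter) lies beyond the scatter and points towards weaker inhibition. Compound 3 also has a six-membered aromatic ring there, so it is expected to remain weak in this assay.

The expected step is an at least 1.2-fold lower number from compound 2 to compound 3 (0.09 log units; that floor lies within the scatter), not clearly beyond the scatter, and the assay may again report only a limit. For compound 3 the estimated value is 16000 nM, with an expected range of 5000 nM to 40000 nM.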

Compound 3, half-maximal inhibitory concentration: > 20000 nM
Compound 3 ended at the assay's limit; the forecaster's own chance of this, stated with the estimate: 45%; at least 1.2-fold (0.09 log units) between middle value and limit.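

The change to 4-aminophenyl in place of bromo gives an at least 2.2-fold higher number from compound 1 to compound 3 (0.35 log units; beyond the scatter) in this assay, which is the same direction as the earlier step to pyridin-4-yl. The earlier loss therefore no longer rests on a single example: among the compounds shown, both six-membered aromatic rings on this carbon leave the compound weaker than compound 1, and the ring of carbon only, which has no ring nitrogen, does so as well. How pyridin-4-yl and 4-aminophenyl compare with each other cannot be read, because compound 2 and compound 3 both stop at a limit of the assay, not at a number: the limit of > 20000 nM in this assay, at which 2 of the 3 values shown sit.

From the compounds shown here alone, it remains open whether any ring on this carbon brings the loss, or whether a small group such as chloro or methoxy in place of bromo would match or improve on compound 1, which gives 8900 nM. Going by these compounds, it is also open how a phenyl ring carrying a carboxylic acid in place of the amine would behave, and only a ring compound with a value inside the range of the assay could give a ring-to-ring comparison a readable size.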